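Hydrogen in Place of Chloro on Compound 2

This account rests on a few compounds, and the source may have more. Where it says the series, first, only, none or still open, it means among the compounds named here.

Measured so far:
compound 1, `COc1ccc(C2CC(Nc3nc4ccccc4s3)=NN2C(C)=O)cc1O`: 259 umol/kg
compound 2, `COc1ccc(C2CC(Nc3nc4ccc(Cl)cc4s3)=NN2C(C)=O)cc1`: 93.3 umol/kg

In a functional assay on the whole organism (Hindlimb, strain albino) with Mus musculus as the target, in the maximal electroshock model, with a stated time of 0.5 h (on this read-out lower numbers stand for an effect already at smaller amounts and higher numbers for an effect only at larger amounts of compound), compound 2 gives 93.3 umol/kg, the lowest of the two numbers. Compound 1 gives 259 umol/kg in this assay, a higher number beyond the scatter. Compound 3, `COc1ccc(C2CC(Nc3nc4ccccc4s3)=NN2C(C)=O)cc1`, differs from compound 2 in one place: hydrogen in place of chloro on an aromatic carbon. Among the measured compounds shown here, compound 1 also carries hydrogen there but differs from compound 3 elsewhere, so no direct step is known. For compound 3 a modest step toward higher numbers is expected, a 1.6-fold higher number from compound 2 to compound 3 (0.21 log units; within the scatter), possibly not beyond the scatter. Compound 3 is estimated at 150 umol/kg, between 70 umol/kg and 320 umol/kg.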

Compound 3, dose for half-maximal effect: 226 umol/kg
The estimate for compound 3 lay 1.5-fold (0.18 log units) below the measured number; the range from low to high includes it.
By their numbers in this assay, from the lowest: compound 2; then compounds 3 and 1 (each within the scatter of the next).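

In this assay, chloro on this aromatic carbon of the fused system matters: hydrogen in its place gives a 2.4-fold higher number from compound 2 to compound 3 (0.38 log units; beyond the scatter), a step beyond the scatter. Hydrogen in place of hydroxy on an aromatic carbon, by contrast, gives a 1.1-fold lower number from compound 1 to compound 3 (0.06 log units; within the scatter), so this second change shows no separable effect. No available data explain either step. On these data alone, whether bromo, methoxy or an amine on the chloro-bearing carbon would match compound 2 remains open. Also open, as far as these compounds go, is whether adding hydroxy to compound 2 would leave its number within the scatter.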